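This account rests on a few compounds, and the source may have more. Where it says the series, first, only, none or still open, it means among the compounds named here.

Measured in a functional assay on HCT-116 cells (Homo sapiens) for cytotoxicity, read by scintillation counting and thymidine incorporation, with a stated time of 72 h; on this read-out lower numbers stand for stronger inhibition and higher numbers for weaker inhibition:
- Compound 1 `C#CC=C(c1cc(OC)cc(OC)c1)c1ccc(OC)c(OC)c1`: > 10000 nM, a limit
- Compound 2 `COc1cc(OC)cc(C(=CC#N)c2ccc(OC)c(OC)c2)c1`: 18 nM

Among the measured compounds shown here, compound 2 holds the only actual number so far. Compound 1 has only a limit, (the limit of > 10000 nM in this assay, at which 1 of the 2 values shown sits).

Compound 3 `COC=C(c1cc(OC)cc(OC)c1)c1ccc(OC)c(OC)c1` differs from compound 2 by methoxy in place of cyano on a double-bonded chain carbon bound to a double-bonded chain carbon. For the measured compounds named here, one measured step bears on this place: an at least 550-fold lower number from compound 1 to compound 2 (2.74 log units; beyond the scatter). Going by the values given here, that large step, the only evidence on this place, says nothing direct about methoxy, yet it shows that losing cyano can be costly in this assay. The expected change is a large one toward weaker inhibition, an 83-fold higher number from compound 2 to compound 3 (1.92 log units; beyond the scatter). The estimate for compound 3 is 1500 nM, within 100 nM to 10000 nM.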

Compound 3, half-maximal inhibitory concentration: > 10000 nM
Compound 3: a limit, no number; the forecaster's own chance of this, stated with the estimate: 35%; middle value at least 6.6-fold (0.82 log units) away from the limit.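

In this assay, methoxy does not replace cyano on a double-bonded chain carbon bound to a double-bonded chain carbon without heavy loss: the change gives an at least 550-fold higher number from compound 2 to compound 3 (2.74 log units; beyond the scatter) at this place. With ethynyl and methoxy both failing, the cost no longer rests on a single replacement, and among the three groups shown only cyano gives a measurable number: the limit of > 10000 nM in this assay, at which 2 of the 3 values shown sit. The step between compound 1 and compound 3 cannot be read, as both values are limits.

Going by these compounds, whether a group other than cyano can hold the number near that of compound 2 remains open. A carboxamide or a primary amine at this place would test how specific the requirement for cyano is.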